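A few compounds are considered here, and "the series" means these few. Any claim that something is new, unique, unknown or untested is made for them only; others in the source may bear on it.

Measured compounds:
- compound 1, `Cc1cc(NC(=O)c2ccc(C#N)cc2)ccc1NS(=O)(=O)C(F)(F)F`: in an ADME assay on HEK293 cells (Homo sapiens) for cytotoxicity, read by MTT assay, with a stated time of 48 h (on this read-out higher numbers stand for weaker inhibition and lower numbers for stronger inhibition), compound 1 gives > 250000 nM, which is a limit of the assay rather than a number.
- compound 2, `CS(=O)(=O)Nc1ccc(NC(=O)c2ccc(C#N)cc2)cc1F`: in this assay compound 2 gives > 250000 nM, again a limit and not a number.

Compound 2 therefore stands at the limit of > 250000 nM in this assay, at which 2 of the 2 values shown sit, and both values shown sit there, so neither compound shows measurable cytotoxicity within the range this assay covers. Among the compounds with values here, no step between two measured compounds is available.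

Compound 3, `N#Cc1ccc(C(=O)Nc2ccc(NS(=O)(=O)C(F)(F)F)c(F)c2)cc1`, has not yet been measured. It differs from compound 2 by trifluoromethyl in place of methyl on a sulfonyl sulfur. Within the data shown here, with both measured values at the limit, there is no measured step to lean on, and the change from compound 2 to compound 3 is expected to leave the read-out at or near that same limit, with no shift beyond the scatter: a number no higher from compound 2 to compound 3 (the limit leaves the size open). Compound 3 is accordingly estimated at 250000 nM, within the range 80000 nM to 400000 nM.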

Compound 3, half-maximal inhibitory concentration: > 250000 nM
Compound 3 gave a limit, no number; the forecaster's own chance of this, stated with the estimate: 85%; the middle value lies on the limit itself.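

Compound 1, compound 2 and compound 3 all give limits rather than numbers, so no step among them can be read in this assay: the limit of > 250000 nM in this assay, at which 3 of the 3 values shown sit.

The compounds shown leave open whether trifluoromethyl in place of methyl on a sulfonyl sulfur, or fluoro in place of methyl on an aromatic carbon, changes this read-out at all.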